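The source may report more compounds than this note shows. Statements on the series, on what has been measured and on what is new or still open speak of the compounds shown alone.

Measured compounds:
- compound 1 `O=S(=O)(Nc1ccc(F)c(C#Cc2cnc3[nH]ncc3c2)c1F)c1ccccc1` — 2100 nM
- compound 2 `O=S(=O)(Nc1ccc(F)c(C#Cc2cnc3ccnn3c2)c1F)c1cccnc1` — 1840 nM
- compound 3 `O=S(=O)(Nc1ccc(F)c(C#Cc2cnc3[nH]nc(C4CC4)c3c2)c1F)c1cccnc1` — 61 nM

The three compounds were tested in a functional assay on COLO 205 cells (Homo sapiens) for antiproliferative activity, read by MTT assay, with a stated time of 68 h; on this read-out lower numbers stand for stronger inhibition and higher numbers for weaker inhibition. Compound 1 gives 2100 nM and compound 2 gives 1840 nM; these two values lie within the scatter of each other, so neither stands apart. Compound 3 gives 61 nM, the lowest of the three numbers, and its distance to both compound 1 and compound 2 is beyond the scatter, so compound 3 is the most potent of the measured set in this assay.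

The next compound, compound 4 `O=S(=O)(Nc1ccc(F)c(C#Cc2cnc3[nH]nc(-c4ccc(F)cc4)c3c2)c1F)c1cccnc1`, keeps the whole of compound 3 apart from one change: 4-fluorophenyl in place of cyclopropyl on an aromatic carbon. For the measured compounds named here, no measured pair shows this kind of change, so there is nothing to read its size from directly. What is known is that the substituted core of compound 3 sits far below the unsubstituted cores of compound 1 and compound 2; whether a 4-fluorophenyl at the same place holds that level, the data do not say.

Compound 4 is expected to stay close to compound 3 in this assay, with the step of a 1.1-fold higher number from compound 3 to compound 4 (0.06 log units; within the scatter) estimated to lie within the scatter or only slightly beyond it. The estimate for compound 4 is 70 nM, within a range from 15 nM to 300 nM.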

Compound 4, half-maximal inhibitory concentration: 166 nM
Compound 4: the middle estimate sits 2.4-fold (0.38 log units) below what was measured; the range from low to high includes it.
By their numbers in this assay, from the lowest: compound 3; then compound 4; then compounds 2 and 1 (each within the scatter of the next).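

In this assay, for the compounds shown here, placing 4-fluorophenyl instead of cyclopropyl on this aromatic carbon of the five-membered aromatic ring gives a 2.7-fold higher number from compound 3 to compound 4 (0.43 log units; beyond the scatter), the first measured step at this position, and it shows that the number responds to the group placed there. The response is modest: the entering group has 7 heavy atoms against 3 and brings a six-membered aromatic ring in place of a three-membered non-aromatic ring, yet compound 4 still reads 166 nM, so this larger aromatic group is accommodated at only a small cost in this cell assay. No measurement shown here accounts for the direction or size of this step.

Going by these compounds alone, with only two groups compared at this carbon, the step cannot be divided among ring size, aromatic character and the fluorine, so it remains open how a plain phenyl would compare with 4-fluorophenyl. On these data alone, it is also open whether a group without a ring, such as a methyl or an amine, would give a number nearer to that of cyclopropyl or of 4-fluorophenyl.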